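Compound 2 to compound 3: dichlorophenyl replaces fluorophenyl

The source may report more compounds than this note shows. Statements on the series, on what has been measured and on what is new or still open speak of the compounds shown alone.

Of the compounds shown here, two have been measured in a functional assay on A549 cells (Homo sapiens) for inhibition, read by MTT assay, with a stated time of 72 h; a higher number here means a weaker inhibitor, a lower number a stronger inhibitor. Compound 1 `CNc1nc(C)c(C(=O)N/N=C/c2cccc(C(F)(F)F)c2)s1` gives only a limit in this assay, namely > 100 ug/mL; this is the limit of > 100 ug/mL in this assay, at which 1 of the 2 values shown sits. Within the data shown here, compound 2 `CN(C(=O)NC(=O)c1ccccc1F)c1nc(C(F)(F)F)c(C(=O)N/N=C/c2cc(C(F)(F)F)cc(C(F)(F)F)c2)s1` is the only compound with an actual number, and in this assay compound 2 gives 5.43 ug/mL, so compound 2 stands alone as the sole measured point of reference. Among the measured compounds shown here, no two measured compounds differ in a single place, so there is no measured step from which the size of a structural change can be read.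

Compound 3 `CN(C(=O)NC(=O)c1ccc(Cl)cc1Cl)c1nc(C(F)(F)F)c(C(=O)N/N=C/c2cc(C(F)(F)F)cc(C(F)(F)F)c2)s1` differs from compound 2 in one place: 2,4-dichlorophenyl in place of 2-fluorophenyl on a carbonyl carbon. Everything else in compound 3 is kept as in compound 2.

For the measured compounds named here, with no measured step available, the expectation rests on compound 2 alone, and the step of a 1.2-fold lower number from compound 2 to compound 3 (0.08 log units; within the scatter) is expected to be small, not beyond the usual scatter in either direction. Compound 3 is therefore estimated at 4.5 ug/mL, with a range expected from 1.5 ug/mL to 14 ug/mL.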

Compound 3, half-maximal inhibitory concentration: > 100 ug/mL
Compound 3 gave a limit, no number; the forecaster's own chance of this, stated with the estimate: 5%; middle value at least 22-fold (1.34 log units) from the limit.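

Among these compounds, the exchange of 2-fluorophenyl for 2,4-dichlorophenyl on a carbonyl carbon is the first change in a single place that can be read in this assay, and it proves far from neutral, giving an at least 18-fold higher number from compound 2 to compound 3 (1.26 log units; beyond the scatter). In this assay, going by these compounds, compound 3 gives > 100 ug/mL, which is a limit and not a number, so the step marks only the smallest size the change can have and its true size stays unknown. The earlier compounds said nothing about this position, whereas this pair shows that the measurable value of compound 2 depends on the aryl group carried by this carbonyl carbon, and that one change in that group is enough to lose a measurable number, leaving compound 2 as the only compound with one: the limit of > 100 ug/mL in this assay, at which 2 of the 3 values shown sit.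

On these data alone, this single step cannot separate the loss of the fluorine from the entry of the two chlorines, so it remains open which part of the exchange matters. It also leaves open how an unsubstituted phenyl, a 2-chlorophenyl or a cyclohexyl group on the same carbonyl carbon would read in this assay, and whether any group there would give a lower number than compound 2.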